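Methyl Ester in Place of Benzylamide: Expected Cytotoxicity

The source may hold more compounds than are shown below. What is called first, only, known or untested is meant among the compounds shown, and "the series" means these compounds.

Within the data shown here, compound 1 `O=C(Nc1ccc(-n2ccc3nc(C(=O)NCc4ccccc4)ccc32)cc1)Nc1ccc(Cl)c(C(F)(F)F)c1` is the only member of this small set that gives a number in an ADME assay on HS27 cells (Homo sapiens) for cytotoxicity, read by MTT assay; on this read-out lower numbers stand for stronger inhibition and higher numbers for weaker inhibition: compound 1 gives 3000 nM. The other two values are limits. Compound 3 `O=C(Nc1ccc(-n2ccc3nc(C(=O)NCc4ccccc4)ccc32)cc1)Nc1cccc(Cl)c1Cl` gives > 10000 nM, which is a limit of the assay rather than a number. Compound 2 `COC(=O)c1ccc2c(ccn2-c2cccc(NC(=O)c3cccc(C(F)(F)F)c3)c2)n1` likewise gives > 10000 nM, again a limit. Among the measured compounds shown here, the one step that can be sized, an at least 3.3-fold higher number from compound 1 to compound 3 (0.52 log units; beyond the scatter), concerns the aryl group on the amide-type nitrogen and not the carbonyl end of the shared core, so it does not bear directly on the change considered here. Compound 4 `COC(=O)c1ccc2c(ccn2-c2ccc(NC(=O)Nc3ccc(Cl)c(C(F)(F)F)c3)cc2)n1` differs from compound 1 at that carbonyl end: methoxy in place of benzylamino on a carbonyl carbon. For the measured compounds named here, no measured pair differs in exactly this way; compound 2 carries the same methoxycarbonyl group but also a different amide linkage, so its value can only hint. Given that hint and (the limit of > 10000 nM in this assay, at which 2 of the 3 values shown sit), weaker inhibition is expected, with a fair chance that compound 4 also returns only a limit. The expected step is a 2.7-fold higher number from compound 1 to compound 4 (0.43 log units; beyond the scatter). Compound 4 is accordingly estimated at 8000 nM, within 3000 nM to 25000 nM.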

Compound 4, half-maximal inhibitory concentration: 8200 nM
Estimate against measurement, compound 4: 1.0-fold (0.01 log units) below; the measured number falls inside the stated range.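

In this assay, the replacement at the carbonyl carbon can now be sized as a single change, methoxy in place of benzylamino, which gives a 2.7-fold higher number from compound 1 to compound 4 (0.44 log units; beyond the scatter). Before this, the methoxycarbonyl group appeared only in compound 2, which gives > 10000 nM, a limit of the assay and not a number. The result shows that the carbonyl end of the shared core, and not only the aryl group on the amide-type nitrogen, affects this read-out, while compound 4 still gives a number short of the limit that holds most of the other values: the limit of > 10000 nM in this assay, at which 2 of the 4 values shown sit.

The benzyl ring and the amide hydrogen leave together in this one change, so the compounds shown do not separate their contributions; a methylamino group or a carboxylic acid at the same carbonyl carbon would bear on that question. Going by these compounds, it also stays open whether this step would be of similar size with the 2,3-dichlorophenyl group of compound 3, for which only a limit is available.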